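This account rests on a few compounds, and the source may have more. Where it says the series, first, only, none or still open, it means among the compounds named here.

In a functional assay on HT-1080 cells (Homo sapiens) for cytotoxicity, read by MTT assay, with a stated time of 72 h (a lower number here means a stronger inhibitor, a higher number a weaker inhibitor), the series reads as follows:
- compound 1 `COc1ccc(/C=C2\CCC/C(=C\c3ccccc3Cl)C2=O)cc1OC` gives 6800 nM
- compound 2 `COc1ccc(/C=C2\CCC/C(=C\c3ccc(Cl)cc3)C2=O)cc1OC` gives 4800 nM
- compound 3 `COc1ccc(/C=C2\CCC/C(=C\c3ccc(OC)c(OC)c3)C2=O)cc1` gives 7200 nM

Compound 3, at 7200 nM, cannot be separated from the other two. The steps that reach it are a 1.1-fold higher number from compound 1 to compound 3 (0.02 log units; within the scatter) and a 1.5-fold higher number from compound 2 to compound 3 (0.18 log units; within the scatter).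

Compound 4 `COc1ccc(/C=C2\CCC/C(=C\c3cccc(O)c3)C2=O)cc1OC` follows from compound 3 by one change (3-hydroxyphenyl in place of 4-methoxyphenyl on a double-bonded chain carbon bound to a double-bonded ring carbon): 3-hydroxyphenyl in place of 4-methoxyphenyl on a double-bonded chain carbon bound to a double-bonded ring carbon.

The measured steps that bear on this change are those two and a 1.4-fold lower number from compound 1 to compound 2 (0.15 log units; within the scatter). All three alter the same aryl group of the shared core, and none goes beyond the scatter. Among the measured compounds shown here, no measured compound carries a 3-hydroxyphenyl group, so the new group is untested here and the range is kept wide. No step beyond the scatter is expected in either direction.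

The estimated step is a 1.3-fold lower number from compound 3 to compound 4 (0.12 log units; within the scatter), which is an expectation only. For compound 4 the expected value is 5500 nM, with an estimated range from 2300 nM to 12000 nM.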

Compound 4, half-maximal inhibitory concentration: 1700 nM
Compound 4: the middle estimate sits 3.2-fold (0.51 log units) above what was measured, outside the stated range (below it).
By their numbers in this assay, from the lowest: compound 4; then compounds 2, 1 and 3 (each within the scatter of the next).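

In this assay, the aryl group on a double-bonded chain carbon bound to a double-bonded ring carbon now gives steps beyond the scatter: a 4.2-fold lower number from compound 3 to compound 4 (0.63 log units; beyond the scatter), a 2.8-fold lower number from compound 2 to compound 4 (0.45 log units; beyond the scatter) and a 4.0-fold lower number from compound 1 to compound 4 (0.60 log units; beyond the scatter). The earlier exchanges at this position all stayed within the scatter, so the flat picture they gave holds only for the chloro- and methoxy-bearing aryl groups, and compound 4 is the strongest inhibitor of the four. No supporting data bear on why 3-hydroxyphenyl lowers the number here.

The entering group counts a hydrogen-bond donor that 4-methoxyphenyl lacks, but one compound cannot tell whether the hydroxyl itself or its place on the ring carries the step. An amine or a carboxylic acid in place of the hydroxyl would test how specific the step is.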